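Ring swap at the saturated carbon of compound 2

The compounds below may be only part of what the source reports. "The series", "measured", "known", "first", "only" and "open" are said of these compounds alone.

Within the data shown here, compound 2 `CC1=C(C(=O)SC(C)C)C(c2ccco2)NC(=O)N1` stands highest of the two numbers known in an assay on membranes from HEK293 cells for displacement of a labelled ligand from adenosine receptor A2b (Homo sapiens), read by scintillation counting, with a stated time of 30 min, tested at 1 uM (on this read-out higher numbers stand for more inhibition at the one concentration tested (going by the name of the read-out) and lower numbers for less inhibition), where compound 2 gives 22%. Compound 1 `CC1=C(C(=O)NC(C)C)C(c2ccsc2)NC(=O)N1` gives 3% in this assay, a gap beyond the scatter. Compound 3 `CC1=C(C(=O)SC(C)C)C(c2ccsc2)NC(=O)N1` differs from compound 2 in one place: thiophen-3-yl in place of furan-2-yl on a saturated ring carbon. Among the measured compounds shown here, no step between measured compounds that differ in one place is known in this set, so only a small step in this assay is expected, in either direction, not clearly beyond the scatter. For compound 3 the estimated value is 18%, with an expected range from 5% to 32%, meaning an expected step of a number 4 percentage points lower from compound 2 to compound 3 (within the scatter).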

Compound 3, a percentage reported as inhibition, at one concentration (the size of the read-out at that concentration, not a potency): 14%
Compound 3: the middle estimate sits 4 percentage points above what was measured, within the range that was stated.
By their numbers in this assay, from the lowest: compound 1; then compounds 3 and 2 (each within the scatter of the next).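

On the saturated ring carbon, thiophen-3-yl in place of furan-2-yl gives a number 8 percentage points lower from compound 2 to compound 3 (within the scatter) in this assay and so does not separate these two rings. Among these compounds, on the carbonyl carbon, isopropylsulfanyl in place of isopropylamino gives a number 11 percentage points higher from compound 1 to compound 3 (beyond the scatter) as the first one-place step beyond the scatter. No measurement at hand offers an explanation for either step.

Still open, going by these compounds, is whether a phenyl ring on the saturated ring carbon, or an ethoxy group on the carbonyl carbon, would shift the number in this assay by more than the scatter.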